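Swapping the Amide of Compound 1 for a Thioamide

A few compounds are considered here, and "the series" means these few. Any claim that something is new, unique, unknown or untested is made for them only; others in the source may bear on it.

In a functional assay on PC-3 cells (Homo sapiens) for cytotoxicity, read by sulforhodamine B assay, with a stated time of 72 h (a higher number here means a weaker inhibitor, a lower number a stronger inhibitor), compound 1 `Nc1sc(-c2ccc(Cl)cc2)c(-c2ccc(Cl)cc2)c1C(=O)NC1CC1` gives 3680 nM.
In this assay compound 2 `Nc1sc(-c2ccc(F)cc2)c(-c2ccc(Cl)cc2)c1C(=O)NC1CC1` gives 28000 nM.

For the measured compounds named here, compound 1 stands at the lowest of the two numbers so far; the only other compound, compound 2, sits at a 7.6-fold higher number from compound 1 to compound 2 (0.88 log units; beyond the scatter), and that step concerns a halogen swap on a phenyl ring. Compound 3 `CC(C)(C)NC(=S)c1c(N)sc(-c2ccc(Cl)cc2)c1-c1ccc(Cl)cc1` changes a different part of the shared core: a group of 7 heavy atoms (5 carbon, 1 nitrogen, 1 sulfur; no ring) in place of a group of 6 heavy atoms (4 carbon, 1 nitrogen, 1 oxygen; one three-membered non-aromatic ring of carbon only), on an aromatic carbon. Going by the values given here, no measured step touches this position, so the halogen step between compound 1 and compound 2 offers no direct guide, and the size and direction of the step from compound 1 to compound 3 remain open. The working expectation is therefore a change of modest size at most, a 1.4-fold higher number from compound 1 to compound 3 (0.13 log units; within the scatter), with a wide margin on either side. On that basis compound 3 is estimated at 5000 nM in this assay, within a range from 1000 nM to 25000 nM.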

Compound 3, half-maximal inhibitory concentration: 34000 nM
Beside the measured number, compound 3's estimate is 6.8-fold (0.83 log units) below it; the whole stated range lies below it.
By their numbers in this assay, from the lowest: compound 1; then compounds 2 and 3 (each within the scatter of the next).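

The carbon bearing the amide group turns out to be sensitive in this assay: a 9.2-fold higher number from compound 1 to compound 3 (0.97 log units; beyond the scatter). For the compounds shown here, this is the first measured change at this position, since the earlier step touched only a halogen on a phenyl ring. The change is a double one, with sulfur taking the place of the carbonyl oxygen and a group with no ring replacing the cyclopropyl ring, so the step belongs to the pair of changes taken together. No measurement shown gives a reason for the step.

Which part of the change carries the step stays open; the thioamide with the cyclopropyl ring kept, or the oxygen amide with a tert-butyl group, would separate the two. How a carboxylic acid or a longer straight chain on this carbon would behave is open as well.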